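The source may hold more compounds than are shown below. What is called first, only, known or untested is meant among the compounds shown, and "the series" means these compounds.

Compound 1 `O=S(=O)(NCCNc1nccc(-c2c(-c3cccc(F)c3)nc3sccn23)n1)c1ccc(Br)cc1` gives 13500 nM in a functional assay on SK-MEL-28 cells (Homo sapiens) for cytotoxicity, read by MTT assay; a lower number here means a stronger inhibitor, a higher number a weaker inhibitor; compound 2 `O=C(NCCNc1nccc(-c2c(-c3cccc(F)c3)nc3sccn23)n1)c1c(F)cccc1F` gives 11400 nM; compound 3 `O=S(=O)(NCCCNc1nccc(-c2c(-c3cccc(F)c3)nc3sccn23)n1)c1ccc(Cl)cc1` gives 8450 nM.

These three share a common core and differ only in the side chain on the amine nitrogen. All three numbers sit within the usual scatter of one another: compound 3 is separated from compound 2 by a 1.3-fold lower number from compound 2 to compound 3 (0.13 log units; within the scatter) and from compound 1 by a 1.6-fold lower number from compound 1 to compound 3 (0.20 log units; within the scatter), so no ordering among them can be read from this assay.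

Compound 4 `O=C(NCCCNc1nccc(-c2c(-c3cccc(F)c3)nc3sccn23)n1)c1ccc(Cl)cc1` is obtained from compound 3 by (4-chlorophenyl)carbonyl in place of (4-chlorophenyl)sulfonyl on an amine nitrogen. Within the data shown here, the closest precedent is the step from compound 1 to compound 2, in which a sulfonyl on the same amine nitrogen was also exchanged for a carbonyl, and that step gave a 1.2-fold lower number from compound 1 to compound 2 (0.07 log units; within the scatter). The step from compound 2 to compound 3, which reverses a carbonyl to a sulfonyl while also lengthening the chain, gave a 1.3-fold lower number from compound 2 to compound 3 (0.13 log units; within the scatter). Neither step moved beyond the scatter, so the exchange of sulfonyl for carbonyl is expected to leave this assay essentially unchanged.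

Compound 4 is therefore estimated at 8500 nM, with a range from 4000 nM to 18000 nM, which amounts to an expected step of a 1.0-fold higher number from compound 3 to compound 4 (0.00 log units; within the scatter).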

Compound 4, half-maximal inhibitory concentration: > 20000 nM
Compound 4 ended at the assay's limit; the forecaster's own chance of this, stated with the estimate: 5%; at least 2.3-fold (0.37 log units) between middle value and limit.
By their numbers in this assay, from the lowest: compounds 3, 2 and 1 (each within the scatter of the next). At a limit, above all of these: compound 4.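

Among these compounds, with the 4-chlorophenyl group kept, (4-chlorophenyl)carbonyl in place of (4-chlorophenyl)sulfonyl on the amine nitrogen gives an at least 2.3-fold higher number from compound 3 to compound 4 (0.37 log units; beyond the scatter) in this assay, the first step in this set to pass beyond the scatter, whereas the earlier exchange of sulfonyl for carbonyl, which also changed the aryl group, gave a 1.2-fold lower number from compound 1 to compound 2 (0.07 log units; within the scatter). In the setting of compound 3, then, carbonyl and sulfonyl are not interchangeable on this nitrogen. Yet a carbonyl there does not by itself give the result seen for compound 4, for compound 2 carries one and gives 11400 nM. The value of compound 4 is a limit and not a number, so the step from compound 3 gives only a floor: the limit of > 20000 nM in this assay, at which 1 of the 4 values shown sits.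

The two further steps, an at least 1.7-fold higher number from compound 2 to compound 4 (0.24 log units; that floor lies within the scatter) and an at least 1.4-fold higher number from compound 1 to compound 4 (0.17 log units; that floor lies within the scatter), cannot be read as differences. Also open, from the compounds shown here alone, is whether the same exchange acts alike on the chain of compound 1, and whether a urea on this nitrogen or a longer chain would stay with compound 3 or go with compound 4.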